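A few compounds are considered here, and "the series" means these few. Any claim that something is new, unique, unknown or untested is made for them only; others in the source may bear on it.

Measured in a functional assay on HeLa cells (Homo sapiens) for cytotoxicity, read by resazurin assay, with a stated time of 24 h; on this read-out higher numbers stand for weaker inhibition and lower numbers for stronger inhibition:
- compound 1 `CS/C=C/C(=O)Nc1ccn([C@H]2CC[C@H](O[C@H]3O[C@H](C)[C@@H](N(C)C)[C@H](O)[C@H]3O)[C@@H](C)O2)c(=O)n1`: 1 ug/mL
- compound 2 `CC[C@H](C)CCC(=O)Nc1ccn([C@H]2CC[C@H](O[C@H]3O[C@H](C)[C@@H](N(C)C)[C@H](O)[C@H]3O)[C@@H](C)O2)c(=O)n1`: > 64 ug/mL

For compound 2 the assay gives only a limit, > 64 ug/mL, and no exact number.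

The next compound, compound 3 `CC(=O)C(C)Nc1ccc(C(=O)Nc2ccn([C@H]3CC[C@H](O[C@H]4O[C@H](C)[C@@H](N(C)C)[C@H](O)[C@H]4O)[C@@H](C)O3)c(=O)n2)cc1`, keeps the shared core and changes only the group on the carbonyl carbon. The change is 4-((1-acetylethyl)amino)phenyl in place of 3-methylpentyl on a carbonyl carbon. In words, 4-((1-acetylethyl)amino)phenyl takes the place of 3-methylpentyl on a carbonyl carbon.

Among the measured compounds shown here, one measured step bears on this place: an at least 64-fold higher number from compound 1 to compound 2 (1.80 log units; beyond the scatter). That step was large, and it came from putting 3-methylpentyl in place of 2-(methylsulfanyl)ethenyl on the same kind of carbonyl carbon. It shows that the group held here can move the number strongly, though this rests on a single pair. On these data alone, the group entering in compound 3 matches neither measured group, so the size of its effect remains open. A modest move towards stronger inhibition is expected, and compound 3 could also return only a limit.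

The expected step is an at least 2.0-fold lower number from compound 2 to compound 3 (0.30 log units; that floor lies within the scatter). Compound 3 is estimated at 32 ug/mL, with an expected range of 8 ug/mL to 64 ug/mL.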

Compound 3, half-maximal inhibitory concentration: 16 ug/mL
Beside the measured number, compound 3's estimate is 2.0-fold (0.30 log units) above it, within the range that was stated.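

In this assay, a group carrying a six-membered aromatic ring on this carbonyl carbon restores a measurable number where the branched chain gave none: putting 4-((1-acetylethyl)amino)phenyl in place of 3-methylpentyl gives an at least 4.0-fold lower number from compound 2 to compound 3 (0.60 log units; beyond the scatter). The true size of that step cannot be stated and only its lower bound is known, because compound 2 sits at a limit of the assay, not at an exact number: the limit of > 64 ug/mL in this assay, at which 1 of the 3 values shown sits. The new group still does not match the small unsaturated sulfur-bearing group, since the change to it gives a 16-fold higher number from compound 1 to compound 3 (1.20 log units; beyond the scatter), so among these three compounds the position gives a graded response, not a simple all-or-nothing one.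

The new group differs from 3-methylpentyl in several ways at once, so the compounds shown cannot say whether the gain comes from the ring, the amine nitrogen or the acetyl carbonyl. On these data alone, it also remains open where a plain phenyl, a 4-aminophenyl or a saturated 2-(methylsulfanyl)ethyl group would fall relative to compound 1 and compound 3.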